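The source may hold more compounds than are shown below. What is called first, only, known or untested is meant among the compounds shown, and "the series" means these compounds.

Compound 1 `COc1ccc(NC(=O)C(=O)c2cn(C(C)C)c3ccccc23)cn1`: 0.0833 h
Compound 2 `COc1ccc(NC(=O)C(=O)c2cn(CC3CCCO3)c3ccccc23)cn1`: 0.567 h
Compound 3 `COCCc1cc(C(=O)C(=O)Nc2ccc(OC)nc2)c2ccccn12`: 0.1 h

All three were tested in an ADME assay on liver (Mus musculus, strain CD-1) for metabolic stability, read by LC-MS, using microsomes and NADPH, with a stated time of 5 min, tested at 1 uM; a lower number here means that the compound disappears faster, a higher number that the compound lasts longer. Compound 2 stands highest of the three numbers; compound 3 comes nearest with a lower number, and compound 1 lies furthest away. Going by the values given here, only one pair of measured compounds differs in a single place, and that step is a 6.8-fold higher number from compound 1 to compound 2 (0.83 log units; beyond the scatter).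

Compound 4 `COCC(C)(C)n1cc(C(=O)C(=O)Nc2ccc(OC)nc2)c2ccccc21` has not yet been measured. It differs from compound 2 in one place: 1-(methoxymethyl)-1-methylethyl in place of (oxolan-2-yl)methyl on an aromatic nitrogen. Among the compounds with values here, the sole measured step that bears on a change at this aromatic nitrogen is a 6.8-fold higher number from compound 1 to compound 2 (0.83 log units; beyond the scatter), and it compared two groups of which neither is the one entering compound 4, so it gives only a scale, not a direction. The entering group keeps the single oxygen of the leaving group but has no ring, and in that respect it resembles the isopropyl of compound 1. On that basis a downward step of modest size is expected, smaller than the measured step, because compound 1 gives 0.0833 h and compound 2 gives 0.567 h, and compound 4 should fall between them. The expected step is a 1.9-fold lower number from compound 2 to compound 4 (0.28 log units; within the scatter). Compound 4 is therefore estimated at 0.3 h, with a range from 0.1 h to 0.8 h.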

Compound 4, half-life: 0.267 h
Compound 4: middle estimate off by 1.1-fold (0.05 log units), on the high side, and the stated range covers the measured number.
By their numbers in this assay, from the lowest: compounds 1 and 3 (each within the scatter of the next); then compound 4; then compound 2.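

In this assay, opening the ring of (oxolan-2-yl)methyl into 1-(methoxymethyl)-1-methylethyl gives a 2.1-fold lower number from compound 2 to compound 4 (0.33 log units; beyond the scatter) even though both groups have the same count of heavy atoms and each holds one oxygen, so at this aromatic nitrogen the number depends on more than those counts. Placing methoxymethyl in place of a hydrogen on the isopropyl of compound 1 gives a 3.2-fold higher number from compound 1 to compound 4 (0.51 log units; beyond the scatter) and so shows that a group without a ring can also stand clearly above isopropyl, though not as high as the ring-bearing group of compound 2. No measurement here explains either step.

The compounds shown do not separate the part played by the oxygen from the part played by the carbon framework: tert-butyl and cyclopentylmethyl on the same nitrogen, both without oxygen, would help to pull the two apart. They also leave open how an amine, a carboxylic acid or a longer ether chain at this nitrogen would behave in this assay, and whether these steps would carry over to the different core of compound 3.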